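Swapping Fluorine for Two Chlorines on a Shared Core

The source may report more compounds than this note shows. Statements on the series, on what has been measured and on what is new or still open speak of the compounds shown alone.

Compound 1 `O=[N+]([O-])c1ccc(Nc2nccc(-c3ccc(F)cc3)n2)cc1` gives 7950 nM in a functional assay on HepG2 cells (Homo sapiens) for antiproliferative activity, read by MTT assay; a lower number here means a stronger inhibitor, a higher number a weaker inhibitor. Among the three measured compounds it stands second highest: compound 3 `COc1cccc(Nc2nccc(-c3ccc(Cl)c(Cl)c3)n2)c1` gives 3370 nM, a lower number beyond the scatter, while compound 2 `COc1cccc(Nc2nccc(-c3ccc(Br)cc3)n2)c1` gives 148000 nM, far higher. Compound 4 `O=[N+]([O-])c1ccc(Nc2nccc(-c3ccc(Cl)cc3Cl)n2)cc1` has not yet been measured. It differs from compound 1 in one place: 2,4-dichlorophenyl in place of 4-fluorophenyl on an aromatic carbon. For the measured compounds named here, compound 3, which also bears chlorine rather than fluorine or bromine, sits below compound 1, whereas compound 2 sits well above it; both differ from compound 1 in other places too, so no clean single-change step is available. A modest downward step, near the edge of the scatter, is expected for a 2.0-fold lower number from compound 1 to compound 4 (0.30 log units; within the scatter). Compound 4 is estimated at 4000 nM, within 1200 nM to 13000 nM.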

Compound 4, half-maximal inhibitory concentration: 99300 nM
For compound 4 the middle estimate is 25-fold (1.39 log units) below the measured one; the measured number lies above the stated range.
By their numbers in this assay, from the lowest: compound 3; then compound 1; then compounds 4 and 2 (each within the scatter of the next).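

On the shared core of compound 1, the aromatic group at this position is not freely exchangeable: in this assay, 2,4-dichlorophenyl in place of 4-fluorophenyl gives a 12-fold higher number from compound 1 to compound 4 (1.10 log units; beyond the scatter) and so makes a large difference to the read-out. For the compounds shown here, this is the first step that changes this position alone, and it shows that replacing one halogen-bearing phenyl with another can markedly weaken the compound. Nothing measured here gives a reason for the rise.

The step changes both the halogen and the substitution pattern at once, so their separate contributions stay unresolved. On these data alone, whether 4-chlorophenyl or 2-chlorophenyl would sit nearer compound 1 or compound 4 remains open.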